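The source may hold more compounds than are shown below. What is called first, only, known or untested is meant among the compounds shown, and "the series" means these compounds.

Of the compounds shown here, two have so far been read in a functional assay on MIA PaCa-2 cells (Homo sapiens) for antiproliferative activity, read by MTT assay, with a stated time of 72 h; on this read-out higher numbers stand for weaker inhibition and lower numbers for stronger inhibition. Compound 1 (`O=C1O/C(=C\Cn2cnc3ccn(C/C=C4\OC(=O)C(OCc5ccccc5)=C4OCc4ccccc4)c3c2=O)C(OCc2ccccc2)=C1OCc1ccccc1`) gives 26200 nM, and compound 2 (`O=C1NC(O)(CCn2cnc3cncc(Br)c32)C(OCc2ccccc2)=C1OCc1ccccc1`) gives 48700 nM. These two numbers lie within the usual scatter of each other, so compound 2 stands level with compound 1, and neither can be ranked ahead of the other.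

The next compound to be read is compound 3 (`Nc1nc(F)c(Cl)c2c1ncn2CCC1(O)NC(=O)C(OCc2ccccc2)=C1OCc1ccccc1`), which differs from compound 2 in one place: a group of 12 heavy atoms (6 carbon, 4 nitrogen, 1 fluorine, 1 chlorine; one five-membered aromatic ring with 2 hetero atoms, one six-membered aromatic ring with 1 hetero atom) in place of a group of 10 heavy atoms (6 carbon, 3 nitrogen, 1 bromine; one five-membered aromatic ring with 2 hetero atoms, one six-membered aromatic ring with 1 hetero atom), on a saturated chain carbon, two bonds along the chain from a saturated ring carbon. Both groups, the one leaving and the one entering, hold one five-membered and one six-membered aromatic ring. Going by the values given here, no measured step between closely related compounds shows what such an exchange does, so the expectation rests only on the two values in hand. With compound 2 at 48700 nM, no step beyond the scatter is expected in this assay, and no firm direction can be argued. The estimated 1.4-fold lower number from compound 2 to compound 3 (0.14 log units; within the scatter) therefore stays within the scatter. For compound 3 the estimated value is 35000 nM, with an expected range of 12000 nM to 90000 nM.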

Compound 3, half-maximal inhibitory concentration: > 100000 nM
Compound 3 was reported as a limit; the forecaster's own chance of this, stated with the estimate: 15%; at least 2.8-fold (0.45 log units) between middle value and limit.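

Compound 3 is reported only as a limit and not as a number, so its step has a lower bound and no upper one: the limit of > 100000 nM in this assay, at which 1 of the 3 values shown sits. In this assay, the exchange on the saturated chain carbon, two bonds along the chain from a saturated ring carbon, gives an at least 2.0-fold higher number from compound 2 to compound 3 (0.31 log units; beyond the scatter). This shows what compound 1 and compound 2 could not: this place does respond to a change of group, and keeping one five-membered and one six-membered aromatic ring in the group does not by itself preserve the read-out.

The compounds shown leave open which part of the exchange carries the step, since the bromine leaves while a fluorine, a chlorine and a further nitrogen enter together, and how far the true value of compound 3 lies past the limit. They also leave open whether a simple phenyl ring, a carboxylic acid or a longer chain at this place would bring the read-out back towards that of compound 2 or take it further away.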